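The source may report more compounds than this note shows. Statements on the series, on what has been measured and on what is new or still open speak of the compounds shown alone.

In a functional assay on OVCAR-3 cells (Homo sapiens) for antiproliferative activity, read by spectrophotometry, with a stated time of 2 days (a higher number here means a weaker inhibitor of growth, a lower number a stronger inhibitor of growth), compound 3 `Cc1cc(F)ccc1Nc1ncc(C(F)(F)F)c(N2Cc3cccc(N(C)S(C)(=O)=O)c3C2)n1` gives > 30000 nM, which is a limit and not a number. Compound 1 `Cc1ccc(Nc2ncc(C(F)(F)F)c(N3Cc4cccc(N(C)S(C)(=O)=O)c4C3)n2)c(Cl)c1` gives > 30000 nM, also a limit. Compound 2 `COc1cc(Nc2ncc(C(F)(F)F)c(N3Cc4cccc(N(C)S(C)(=O)=O)c4C3)n2)c(OC)cc1Cl` gives > 30000 nM, again a limit. The three compounds thus stand together at the limit of > 30000 nM in this assay, at which 3 of the 3 values shown sit.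

Compound 4 `COc1cc(Nc2ncc(C(F)(F)F)c(N3Cc4cccc(N(C)S(C)(=O)=O)c4C3)n2)cc(OC)c1` keeps the shared core and changes only the aromatic group on the nitrogen: 3,5-dimethoxyphenyl in place of 4-fluoro-2-methylphenyl on a nitrogen on an aromatic ring. The nearest guide is a step that the two limits leave unreadable from compound 2 to compound 3, in which 4-fluoro-2-methylphenyl replaces a group that also carries two methoxy substituents. The other two changes of this group are a step that the two limits leave unreadable from compound 1 to compound 2 and a step that the two limits leave unreadable from compound 1 to compound 3. None of these steps has a readable size, so none gives a size or a direction to carry over, and no step beyond the scatter is expected in this assay. The expected step is a number no higher from compound 3 to compound 4 (the limit leaves the size open). Compound 4 may well be reported only as a limit again. For compound 4 the estimated value is 30000 nM, with an expected range from 10000 nM to 50000 nM.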

Compound 4, concentration for 50% growth inhibition: 630 nM
The estimate for compound 4 lay 48-fold (1.68 log units) above the measured number; the measured number lies below the stated range.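

In this assay, going by these compounds alone, no step among compounds 1, 2 and 3 can be read, so those compounds said nothing about this position; 3,5-dimethoxyphenyl now shows that the group on this nitrogen can change the result greatly, with an at least 47-fold lower number from compound 3 to compound 4 (1.67 log units; beyond the scatter). The same group gives an at least 47-fold lower number from compound 1 to compound 4 (1.67 log units; beyond the scatter) and an at least 47-fold lower number from compound 2 to compound 4 (1.67 log units; beyond the scatter), and the last step shows that carrying two methoxy groups is not enough in itself, as the 4-chloro-2,5-dimethoxyphenyl of compound 2 has them too. Compound 4 alone gives a number, while the others remain at a limit: the limit of > 30000 nM in this assay, at which 3 of the 4 values shown sit.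

The compounds shown cannot tell whether the gain in compound 4 depends on where the methoxy groups sit or on the absence of chlorine. From the compounds shown here alone, whether 3,5-diethoxyphenyl, or a ring with an amine in place of one methoxy group, would keep this activity also remains open.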